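Methoxy added to the aryl ring of compound 1

This account rests on a few compounds, and the source may have more. Where it says the series, first, only, none or still open, it means among the compounds named here.

compound 1 `O=C1COc2ccc(-c3cnc4ccccc4c3)cc2N1c1ccccc1`: > 40000 nM (a limit, not a number)
compound 2 `O=C1COc2ccc(-c3cnc(Cl)c(NS(=O)(=O)c4ccc(F)cc4)c3)cc2N1c1ccc(F)cc1`: 34200 nM
compound 3 `O=C1COc2ccc(-c3cnc(Cl)c(NS(=O)(=O)c4ccc(F)cc4)c3)cc2N1c1ccc(Cl)cc1`: 27900 nM

In a functional assay on HCT-116 cells (Homo sapiens) for antiproliferative activity, read by MTT assay, with a stated time of 72 h (a higher number here means a weaker inhibitor, a lower number a stronger inhibitor), compound 1 gives only a limit, > 40000 nM, so where it stands among the numbers is not known (the limit of > 40000 nM in this assay, at which 1 of the 3 values shown sits). Compound 4 `COc1cccc(N2C(=O)COc3ccc(-c4cnc5ccccc5c4)cc32)c1` differs from compound 1 by methoxy in place of hydrogen on an aromatic carbon. Within the data shown here, the single measured step, a 1.2-fold lower number from compound 2 to compound 3 (0.09 log units; within the scatter), concerns a different pair and a different change, so no measured step bears on methoxy in place of hydrogen. Among the measured compounds shown here, with compound 1 at the limit and no comparable step to lean on, no shift beyond the scatter is expected in this assay, and compound 4 is expected to sit near the same limit, a step that the limit leaves unreadable from compound 1 to compound 4. The estimate for compound 4 is 45000 nM, within 15000 nM to 150000 nM.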

Compound 4, half-maximal inhibitory concentration: 8240 nM
Compound 4: the middle estimate sits 5.5-fold (0.74 log units) above what was measured; measured number outside the range, below it.
By their numbers in this assay, from the lowest: compound 4; then compounds 3 and 2 (each within the scatter of the next). At a limit, above all of these: compound 1.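

In this assay, phenyl to 3-methoxyphenyl gives an at least 4.8-fold lower number from compound 1 to compound 4 (0.68 log units; beyond the scatter), so this aromatic carbon, meta to a large group, is a place where a small change can register. Among these compounds, the only earlier step, a 1.2-fold lower number from compound 2 to compound 3 (0.09 log units; within the scatter), involved a different change on a different pair. The true size of the new step stays unknown because compound 1 stands at a limit: the limit of > 40000 nM in this assay, at which 1 of the 4 values shown sits.

As far as these compounds go, whether an amine, a hydroxyl or an ethoxy chain at this place would move the number as methoxy does remains open. So does whether methoxy would have any such effect on compound 2 or compound 3.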